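Shortening the Linker Between Core and Phenyl in Compound 2

The source may hold more compounds than are shown below. What is called first, only, known or untested is meant among the compounds shown, and "the series" means these compounds.

Compound 1 `CC(CC(=O)O)CC(=O)n1c(CCCc2ccccc2)cc2ccc(Cl)cc21` gives 210 nM in a functional assay for antagonist activity at Oxoeicosanoid receptor 1 (Homo sapiens), read by fluorescence and calcium flux, with stated times of 2 min and 1 min; a lower number here means a stronger inhibitor, a higher number a weaker inhibitor.
Compound 2 `CC(CC(=O)O)CC(=O)n1c(CCCCCCc2ccccc2)cc2ccc(Cl)cc21` gives 12 nM in this assay.

Of these two numbers compound 2 holds the lower one, and its distance from compound 1 is clearly beyond the scatter. Among the compounds with values here, the one measured step, an 18-fold lower number from compound 1 to compound 2 (1.24 log units; beyond the scatter), adds three chain carbons between the shared core and the phenyl ring. Compound 3 `CC(CC(=O)O)CC(=O)n1c(CCCCCc2ccccc2)cc2ccc(Cl)cc21` is the intermediate case: it differs from compound 2 by phenyl in place of benzyl on a saturated chain carbon, five bonds along the chain from an aromatic carbon, so its chain is one carbon shorter than that of compound 2 and two longer than that of compound 1. With only these two points to go on, the change is expected to nudge the number upward from compound 2, probably by less than the full measured step and perhaps within the scatter, an expected step of a 2.5-fold higher number from compound 2 to compound 3 (0.40 log units; beyond the scatter). Compound 3 is therefore estimated at 30 nM, with a likely range from 10 nM to 90 nM.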

Compound 3, half-maximal inhibitory concentration: 2.1 nM
Compound 3: middle estimate off by 14-fold (1.15 log units), on the high side, outside the stated range (below it).
By their numbers in this assay, from the lowest: compound 3; then compound 2; then compound 1.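

The response to chain length at this position is not steady: phenyl in place of benzyl on the saturated chain carbon gives a 5.7-fold lower number from compound 2 to compound 3 (0.76 log units; beyond the scatter) in this assay, the opposite direction to the step from compound 1 to compound 2. The intermediate chain of compound 3 therefore holds the lowest number of the three, and the span from the shortest chain to this one is a 100-fold lower number from compound 1 to compound 3 (2.00 log units; beyond the scatter) across the series. Longer is thus not simply better, with compound 2 going against that rule, and small changes in chain length move the number far beyond the scatter.

Still open, on these data alone, is whether a 4-phenylbutyl chain, or an ether oxygen placed within the chain, would keep or lower the number. Nothing measured here explains why the chain of compound 3 gives the lowest number.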